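Piperazine variations at the aromatic carbon of the shared core

The source may hold more compounds than are shown below. What is called first, only, known or untested is meant among the compounds shown, and "the series" means these compounds.

Compound 2 `CN(C[C@H]1Cc2c(cccc2N2CCNC(C)(C)C2)CN1)[C@H]1CCCc2cccnc21` is recorded in a functional assay on CCRF-CEM cells for agonist activity at C-X-C chemokine receptor type 4 (Homo sapiens), read by calcium flux, with a stated time of 25 min (on this read-out higher numbers stand for an effect only at larger amounts of compound and lower numbers for an effect already at smaller amounts), only as a limit: compound 2 gives > 30000 nM. Compound 1 `CN(C[C@H]1Cc2c(cccc2N2CCN(C3COC3)CC2)CN1)[C@H]1CCCc2cccnc21` stands at the same limit, compound 1 giving > 30000 nM. Compound 3 `FC1(F)CCC(CN(C[C@H]2Cc3c(cccc3N3CCNCC3)CN2)[C@H]2CCCc3cccnc32)CC1` is likewise a limit, compound 3 giving > 30000 nM. Going by the values given here, the one step between measured compounds, a step that the two limits leave unreadable from compound 1 to compound 2, cannot be read because of the limit of > 30000 nM in this assay, at which 3 of the 3 values shown sit. Compound 4 `CCN1CCN(c2cccc3c2C[C@H](CN(C)[C@H]2CCCc4cccnc42)NC3)CC1` differs from compound 2 by 4-ethylpiperazin-1-yl in place of 3,3-dimethylpiperazin-1-yl on an aromatic carbon. Among the compounds with values here, no measured step bears on this change with a readable size, since every value shown sits at the limit named in the limit of > 30000 nM in this assay, at which 3 of the 3 values shown sit. Compound 4 is therefore expected to remain at that limit, the expected step of a number no higher from compound 2 to compound 4 (the limit leaves the size open) being nothing readable. The estimate for compound 4 is 30000 nM, within 10000 nM to 100000 nM.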

Compound 4, half-maximal effective concentration: > 30000 nM
Compound 4 gave a limit, no number; the forecaster's own chance of this, stated with the estimate: 85%; the middle value lies on the limit itself.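

Going by these compounds alone, compound 4, like compound 1 and compound 2, stands only at a limit, so no step among them can be read: the limit of > 30000 nM in this assay, at which 4 of the 4 values shown sit. Going by these compounds, whether any piperazine variation on the shared core gives a measurable half-maximal effective concentration in this assay remains open.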